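Swapping the Side-Chain Ester for a Protected Amine

The compounds below may be only part of what the source reports. "The series", "measured", "known", "first", "only" and "open" are said of these compounds alone.

Measured so far:
- compound 1, `O=C(CN(c1ncnc2c1ncn2C1CCCCO1)C1CC1)N[C@@H](CCC(=O)OCc1ccccc1)C(=O)OCc1ccccc1`, gives 25.2% in a functional assay on the whole organism (Tail, strain ICR) with Mus musculus as the target, in the tail flick test, with a stated time of 90 min, at a dose of 25 umol/kg by the oral route; a lower number here means a weaker effect, a higher number a stronger effect of the compound at the dose given
- compound 2, `O=C(CN(c1nc(Cl)nc2[nH]cnc12)C1CC1)N[C@@H](CCC(=O)OCc1ccccc1)C(=O)OCc1ccccc1`, gives 50%
- compound 3, `CC[C@H](C)[C@H](NC(=O)CN(c1nc(Cl)nc2[nH]cnc12)C1CC1)C(=O)OCc1ccccc1`, gives 36.3%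

Compound 1 stands lowest of the three numbers in this assay. Compound 3 is nearest, and compound 2 is furthest above it, both gaps beyond the scatter.

Compound 4, `CC(C)(C)OC(=O)NCCCC[C@H](NC(=O)CN(c1ncnc2c1ncn2C1CCCCO1)C1CC1)C(=O)OCc1ccccc1`, is not yet measured. It differs from compound 1 by one change: 2-((tert-butoxycarbonyl)amino)ethyl in place of benzyloxycarbonyl on a saturated chain carbon, three bonds along the chain from an amide-type nitrogen and a carbonyl carbon.

Among the compounds with values here, only one measured step touches the same side chain: a number 13.7 percentage points lower from compound 2 to compound 3 (beyond the scatter). That step, on a different core, shows the side chain can move the read-out modestly. Within the data shown here, no measured step shows this particular exchange, and nothing ties a protected amine on this chain to a direction.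

Compound 4 is therefore expected to sit close to compound 1, with the step of a number 2.2 percentage points lower from compound 1 to compound 4 (within the scatter) expected to stay near or within the scatter. The estimate for compound 4 is 23%, within a range from 8% to 40%.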

Compound 4, a percentage reported as activity, at one dose (the size of the read-out at that dose, not a potency): 32.9%
Beside the measured number, compound 4's estimate is 9.9 percentage points below it, within the range that was stated.
By their numbers in this assay, from the lowest: compounds 1, 4 and 3 (each within the scatter of the next, the first and the last beyond it); then compound 2.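

In this assay, replacing benzyloxycarbonyl with 2-((tert-butoxycarbonyl)amino)ethyl gives a number 7.7 percentage points higher from compound 1 to compound 4 (within the scatter) and so does not separate the two compounds. The position therefore tolerates losing the aromatic ring of the side chain and gaining a nitrogen-bearing chain, at least at this one dose and time. Within the data shown here, the only earlier step on this side chain, a number 13.7 percentage points lower from compound 2 to compound 3 (beyond the scatter) on a different core, had sec-butyl as the entering group, so this is the first view of the position on this core. No data here explain the result.

Going by these compounds, it remains open whether a free amine in place of the protected amine, or a carboxylic acid at the end of the chain, would shift the read-out. On these data alone, it is also open whether the same exchange would read alike on the core of compound 2.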